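The compounds below may be only part of what the source reports. "The series", "measured", "known", "first", "only" and "open" are said of these compounds alone.

Of the compounds shown here, three have been tested in an ADME assay on J774.1 cells (Mus musculus) for cytotoxicity, with a stated time of 48 h; a lower number here means that less compound is needed, a higher number that more compound is needed for the effect. Compound 1, `Clc1cccc(Cl)c1CO/N=C/C1CCN(CCCc2ccccc2)CC1`, gives 28.4 uM in this assay. Compound 2, `COC(=O)c1c(-c2ccccn2)n(Cc2ccc(C)cc2)c(-c2ccccn2)cc1=O`, has "not determined" (no result reported) in this assay. Compound 3, `COC(=O)C1C(=O)C(C(=O)OC)[C@H](c2ccccn2)N(CCCC(=O)O)[C@@H]1c1ccccn1`, gives 46 uM in this assay, which sits alongside the number of compound 1 within the usual scatter, so the two cannot be told apart on these data.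

Compound 4, `C=CCN1[C@H](c2ccccn2)C(C(=O)OC)C(=O)C(C(=O)OC)[C@@H]1c1ccccn1`, has not yet been measured. It differs from compound 3 in one place: vinyl in place of 2-carboxyethyl on a saturated chain carbon bound to an amine nitrogen in a ring. Among the compounds with values here, no measured pair shows this change, so no reference step exists. Compound 4 is expected to shift only modestly, with the step of a 1.5-fold lower number from compound 3 to compound 4 (0.19 log units; within the scatter) not clearly beyond the scatter. Compound 4 is therefore estimated at 30 uM, within 10 uM to 90 uM.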

Compound 4, concentration for half-maximal effect: > 100 uM
Compound 4 gave a limit, no number; the forecaster's own chance of this, stated with the estimate: 10%; middle value at least 3.3-fold (0.52 log units) away from the limit.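

In this assay compound 4 gives a limit and not a number: > 100 uM. Putting vinyl in place of 2-carboxyethyl on a saturated chain carbon bound to an amine nitrogen in a ring gives an at least 2.1-fold higher number from compound 3 to compound 4 (0.33 log units; beyond the scatter), so at this position the number does not fall when the carboxylic acid goes. The full size of this step stays unknown, since one end of it is a limit: the limit of > 100 uM in this assay, at which 1 of the 4 values shown sits.

The compounds shown do not separate losing the carboxylic acid from shortening the chain. A plain propyl chain, or a chain ending in an amine, at this position would help to tell these apart.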